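Removing One Methyl from Compound 2

The source may report more compounds than this note shows. Statements on the series, on what has been measured and on what is new or still open speak of the compounds shown alone.

Of the compounds shown here, two have been measured in an assay on BaF3 cells for inhibition of thrombopoietin receptor (Homo sapiens), tested at 300 nM; on this read-out higher numbers stand for a stronger effect at the one concentration tested and lower numbers for a weaker effect. Compound 1 `C/C(NNC(=S)N1CCc2cc(C(=O)O)ccc21)=C1/C(=O)N(c2ccc3c(c2)CCC3)c2ccc(F)cc21` gives 10.6%. Compound 2 `C/C(NNC(=S)N1CCCc2cc(C(=O)O)ccc21)=C1/C(=O)N(c2ccc(C)c(C)c2)c2ccccc21` gives 33.4%, the higher of the two numbers, with compound 1 lying below it by a gap beyond the usual scatter. Compound 3 `C/C(NNC(=S)N1CCCc2cc(C(=O)O)ccc21)=C1/C(=O)N(c2ccc(C)cc2)c2ccccc21` differs from compound 2 by hydrogen in place of methyl on an aromatic carbon, the 3,4-dimethylphenyl becoming 4-methylphenyl. For the measured compounds named here, no measured pair isolates this change, so a small step is expected, likely a modest loss in this assay or none beyond the scatter, as a number 8.4 percentage points lower from compound 2 to compound 3 (within the scatter). Compound 3 is therefore estimated at 25%, within 8% to 42%.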

Compound 3, a percentage reported as inhibition, at one concentration (the size of the read-out at that concentration, not a potency): 101%
Compound 3: the middle estimate sits 76 percentage points below what was measured; measured number above the stated range.
By their numbers in this assay, from the lowest: compound 1; then compound 2; then compound 3.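

The change from 3,4-dimethylphenyl to 4-methylphenyl gives a number 67.6 percentage points higher from compound 2 to compound 3 (beyond the scatter), so this one aromatic carbon, ortho to a methyl group and meta to a large group, is far from a minor site on this read-out. A single methyl there separates a partial effect from a full one, and hydrogen is the better of the two substituents shown. The compounds shown leave open how a fluorine, a hydroxyl or a methoxy group would fare on that carbon, and whether removing the remaining methyl would help further. Nothing available explains why this step is so large.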